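Swapping a hydroxyethyl for an ester chain

The source may report more compounds than this note shows. Statements on the series, on what has been measured and on what is new or still open speak of the compounds shown alone.

Measured compounds:
compound 1 `COc1cccc(C(=O)N[C@@H](CCC2CCCCC2)C(=O)N[C@@H](CO)CN2CCc3cc(F)ccc32)c1`: 50 nM
compound 2 `COc1cccc(C(=O)N[C@@H](CCC2CCCCC2)C(=O)N[C@H](CN2CCc3cc(F)ccc32)[C@@H](C)O)c1`: 8 nM

In an assay on isolated protein for inhibition of cathepsin S (Homo sapiens) (a lower number here means a stronger inhibitor, a higher number a weaker inhibitor), compound 2 gives 8 nM, the lowest of the two numbers; compound 1 gives 50 nM, and the step of a 6.3-fold lower number from compound 1 to compound 2 (0.80 log units; beyond the scatter) showed that adding a methyl at this position helped. Compound 3 `CCOC(=O)C[C@@H](CN1CCc2cc(F)ccc21)NC(=O)[C@H](CCC1CCCCC1)NC(=O)c1cccc(OC)c1` carries a different change at the same place: (ethoxycarbonyl)methyl in place of 1-hydroxyethyl on a saturated chain carbon bound to an amide-type nitrogen and a saturated chain carbon. Among the measured compounds shown here, the hydroxyl is lost and a longer ester chain enters, which no measured step covers directly. Compound 3 is therefore expected to give a weaker result, estimated at 60 nM (range 15 nM to 250 nM), a step of a 7.5-fold higher number from compound 2 to compound 3 (0.88 log units; beyond the scatter).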

Compound 3, inhibition constant: 16 nM
Compound 3: the middle estimate sits 3.8-fold (0.57 log units) above what was measured, within the range that was stated.
By their numbers in this assay, from the lowest: compounds 2 and 3 (each within the scatter of the next); then compound 1.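

In this assay, (ethoxycarbonyl)methyl serves about as well as 1-hydroxyethyl at this place: a 2.0-fold higher number from compound 2 to compound 3 (0.30 log units; within the scatter), so the two cannot be told apart, and a hydrogen-bond donor in this group is not needed to reach this level. Ethoxycarbonyl in place of hydroxy also gives a real gain, with a 3.1-fold lower number from compound 1 to compound 3 (0.49 log units; beyond the scatter). Nothing measured here explains why the ester chain is accepted. As far as these compounds go, it remains open whether a carboxylic acid or a primary amide in place of the ester would keep this level. From the compounds shown here alone, a longer ester chain is equally open.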